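Taking the methyl off compound 1

This account rests on a few compounds, and the source may have more. Where it says the series, first, only, none or still open, it means among the compounds named here.

Compound 1 `Cc1ccccc1Nc1nc(Nc2ccc(N3CCN(C)CC3)cn2)ncc1Cl` gives 8080 nM
Compound 2 `Cc1ccccc1Nc1nc(Nc2ccc(N3CCCCC3)cn2)ncc1Cl` gives > 100000 nM (a limit of the assay)
Compound 3 `CN1CCN(c2ccc(Nc3ncc(Cl)c(Nc4ccccc4)n3)nc2)CC1` is not yet measured

Among the measured compounds shown here, in a functional assay on Jurkat cells (Homo sapiens) for inhibition, read by CCK-8 assay, with a stated time of 48 h (a higher number here means a weaker inhibitor of growth, a lower number a stronger inhibitor of growth), compound 1 gives 8080 nM as the only actual number so far. Compound 2 sits at the limit of > 100000 nM in this assay, at which 1 of the 2 values shown sits, and no number is known for it.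

Compound 3 keeps the rest of compound 1 and changes one place (hydrogen in place of methyl on an aromatic carbon), with hydrogen in place of methyl on an aromatic carbon, so that 2-methylphenyl becomes phenyl. For the measured compounds named here, the only measured step, an at least 12-fold higher number from compound 1 to compound 2 (1.09 log units; beyond the scatter) with piperidin-1-yl in place of 4-methylpiperazin-1-yl, is large, but it leaves the 2-methylphenyl untouched. Going by the values given here, no measured step covers this change, so no clear direction can be given. The expected step is a 1.1-fold higher number from compound 1 to compound 3 (0.05 log units; within the scatter) in this assay with wide uncertainty. Compound 3 is expected at 9000 nM with an estimated range from 3000 nM to 30000 nM for now.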

Compound 3, concentration for 50% growth inhibition: > 100000 nM
Compound 3 gave a limit, no number; the forecaster's own chance of this, stated with the estimate: 8%; middle value at least 11-fold (1.04 log units) from the limit.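

In this assay, the 2-methylphenyl of compound 1 proves not to be a passive part of the molecule: hydrogen in place of methyl on this aromatic carbon, ortho to a large group, gives an at least 12-fold higher number from compound 1 to compound 3 (1.09 log units; beyond the scatter). Until now, only the other end of compound 1 had been shown to matter, with an at least 12-fold higher number from compound 1 to compound 2 (1.09 log units; beyond the scatter). The full size of the new step stays unknown, since the entry for compound 3 is a limit and not a number: the limit of > 100000 nM in this assay, at which 2 of the 3 values shown sit.

From the compounds shown here alone, it remains open whether chloro, methoxy or ethyl in place of this methyl would keep a measurable value in this assay. Among the compounds shown here, it is equally open whether a larger group there, such as isopropyl, would give a lower number than compound 1, which so far holds the only actual value at 8080 nM.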